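Allyl for Butyl on the Benzyl Arm

A few compounds are considered here, and "the series" means these few. Any claim that something is new, unique, unknown or untested is made for them only; others in the source may bear on it.

Among the compounds with values here, compound 2 `CCCCc1cc(Cn2c(CC)nc3c(C)cc(C)nc32)ccc1OC(C(=O)O)c1ccccc1` gives 140 nM in an assay on Midbrain with Type-2 angiotensin II receptor (Rattus norvegicus) as the target (a higher number here means a weaker inhibitor, a lower number a stronger inhibitor), the lowest of the two numbers so far. Compound 1 `CCc1nc2c(C)cc(C)nc2n1Cc1ccc(OC(C(=O)O)c2ccccc2)c(C)c1` gives 940 nM, and the step of a 6.7-fold lower number from compound 1 to compound 2 (0.83 log units; beyond the scatter) shows that a longer saturated chain at this position lowers the number. Compound 3 `C=CCc1cc(Cn2c(CC)nc3c(C)cc(C)nc32)ccc1OC(C(=O)O)c1ccccc1` differs from compound 2 by vinyl in place of propyl on a saturated chain carbon bound to an aromatic carbon, a shorter and unsaturated chain at the place where the propyl had helped. Within the data shown here, only that one step bears on it, so compound 3 is expected to lose part of that gain, a step of a 2.1-fold higher number from compound 2 to compound 3 (0.33 log units; beyond the scatter) toward a higher number. The estimate for compound 3 is 300 nM, ranging from 120 nM to 800 nM.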

Compound 3, half-maximal inhibitory concentration: 270 nM
The estimate for compound 3 lay 1.1-fold (0.05 log units) above the measured number; the range from low to high includes it.
By their numbers in this assay, from the lowest: compounds 2 and 3 (each within the scatter of the next); then compound 1.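

In this assay, the step of a 1.9-fold higher number from compound 2 to compound 3 (0.29 log units; within the scatter) shows that the butyl-to-allyl change, which both shortens the chain and adds a double bond, leaves compound 2 and compound 3 within the scatter of each other. The step of a 3.5-fold lower number from compound 1 to compound 3 (0.54 log units; beyond the scatter) shows that the allyl chain, like the butyl chain, keeps a clear difference from compound 1. No evidence on hand explains this result. The compounds shown leave the separate shares of chain length and the double bond unresolved. As far as these compounds go, how a longer chain or an amine would fare at this position also remains open.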